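Benzyloxy in place of propoxy on the pendant aromatic ring

The source may hold more compounds than are shown below. What is called first, only, known or untested is meant among the compounds shown, and "the series" means these compounds.

Compound 1 `CCOC(=O)c1c(-c2cccc(C)c2)[nH]c2cc(OC)ccc2c1=O` gives in an ADME assay on Raji cells (Homo sapiens) for cytotoxicity, read by luminescence, with a stated time of 72 h (a lower number here means that less compound is needed, a higher number that more compound is needed for the effect), only a limit, > 21500 nM. Compound 2 `CCCOc1cccc(-c2[nH]c3cc(OC)ccc3c(=O)c2C(=O)OCC)c1` likewise gives in this assay only a limit, > 21500 nM. For the measured compounds named here, the single measured step, a step that the two limits leave unreadable from compound 1 to compound 2, is therefore not readable in size, since both values sit at the limit of > 21500 nM in this assay, at which 2 of the 2 values shown sit. Compound 2 thus stands at the limit, and no number is known for it in this assay.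

Compound 3 `CCOC(=O)c1c(-c2cccc(OCc3ccccc3)c2)[nH]c2cc(OC)ccc2c1=O` differs from compound 2 by phenyl in place of ethyl on a saturated chain carbon bound to an oxygen on an aromatic ring. Going by the values given here, no measured step bears on this change: the only step recorded lies between two limits and tells nothing of direction or size. With both measured compounds at the limit, nothing in the data points to a step beyond the scatter in either direction, and the most that can be said is that compound 3 is expected to remain near or at the limit in this assay. The step from compound 2 to compound 3 is estimated as a step that the limit leaves unreadable from compound 2 to compound 3. Compound 3 is estimated at 30000 nM, with a range from 8000 nM to 100000 nM.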

Compound 3, half-maximal effective concentration: > 21500 nM
Compound 3: no number, only a limit; the forecaster's own chance of this, stated with the estimate: 75%; the middle value is on the limit's open side.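

In this assay compound 3 gives only a limit, > 21500 nM. Neither the step from compound 2 to compound 3 nor that from compound 1 to compound 3 can be read in size, because all the values sit at one limit: the limit of > 21500 nM in this assay, at which 3 of the 3 values shown sit.

The compounds shown leave open whether methyl, propoxy and benzyloxy differ at all in this assay.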